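Cyclopropyl in place of ethyl on a carbonyl carbon

A few compounds are considered here, and "the series" means these few. Any claim that something is new, unique, unknown or untested is made for them only; others in the source may bear on it.

Compound 1 `CC(=O)C(=O)C(NC(=O)[C@@H]1CCCN1C(=O)[C@@H](NC(=O)OC(C)(C)C)C(C)C)C(C)C` and compound 2 `CCC(=O)C(=O)C(NC(=O)[C@@H]1CCCN1C(=O)[C@@H](NC(=O)OC(C)(C)C)C(C)C)C(C)C` share one core, compound 2 carrying a methyl where compound 1 carries hydrogen. In an assay on isolated protein for inhibition of Trypsin (Homo sapiens), with stated times of 15 min, 15 s and 5 min (a higher number here means a weaker inhibitor, a lower number a stronger inhibitor), compound 1 gives only a limit, > 500000 nM. In this assay compound 2 likewise reaches only a limit, > 500000 nM. The step that the two limits leave unreadable from compound 1 to compound 2 is thus unreadable, since the limit of > 500000 nM in this assay, at which 2 of the 2 values shown sit, shows both values sitting at the limit. Compound 3 `CC(C)C(NC(=O)[C@@H]1CCCN1C(=O)[C@@H](NC(=O)OC(C)(C)C)C(C)C)C(=O)C(=O)C1CC1` differs from compound 2 by cyclopropyl in place of ethyl on a carbonyl carbon. No readable measured step bears on this change. Compound 3 is therefore expected to stay at the limit, with a number no higher from compound 2 to compound 3 (the limit leaves the size open) expected to be none beyond the scatter. The estimate for compound 3 is 500000 nM, within 100000 nM to 2000000 nM.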

Compound 3, half-maximal inhibitory concentration: > 500000 nM
Compound 3 gave a limit, no number; the forecaster's own chance of this, stated with the estimate: 85%; the middle value sits exactly at the limit.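

No step among compound 1, compound 2 and compound 3 can be read in this assay, as each gives only a limit: the limit of > 500000 nM in this assay, at which 3 of the 3 values shown sit.

The compounds shown leave open whether any group on this carbonyl carbon gives a number in this assay.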